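This account rests on a few compounds, and the source may have more. Where it says the series, first, only, none or still open, it means among the compounds named here.

Compound 1 `CCOC(=O)C(=O)CC(=O)/C=C/c1cn(CCC(C)C)c2ccccc12` gives in an assay on isolated protein for inhibition of DNA nucleotidylexotransferase (Homo sapiens), read by scintillation counting, with a stated time of 10 min (a lower number here means a stronger inhibitor, a higher number a weaker inhibitor), only a limit, > 40 uM.
Compound 2 `C=C(C)Cn1cc(/C=C/C(=O)CC(=O)C(=O)OCC)c2ccccc21` gives in this assay only a limit, > 40 uM.
Compound 3 `CCOC(=O)C(=O)CC(=O)/C=C/c1cn(Cc2ccccc2)c2ccccc12` gives in this assay only a limit, > 40 uM.

Compound 1 therefore stands at a limit of this assay, not at a number; it is neither stronger nor weaker than the others on what is shown, since all three sit on the same limit (the limit of > 40 uM in this assay, at which 3 of the 3 values shown sit). The measured steps, a step that the two limits leave unreadable from compound 1 to compound 2, a step that the two limits leave unreadable from compound 1 to compound 3 and a step that the two limits leave unreadable from compound 2 to compound 3, each swap one group on the saturated chain carbon bound to an aromatic nitrogen, and each remains unreadable for that reason.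

Compound 4 `CCOC(=O)C(=O)CC(=O)/C=C/c1cn(CC(=O)N2CCOCC2)c2ccccc12` changes the same position: (morpholin-4-yl)carbonyl in place of isobutyl on a saturated chain carbon bound to an aromatic nitrogen. The three measured steps bear on it only in place, not in size or direction, so no shift beyond the scatter can be read from them. Compound 4 is expected to stay at the limit as well, with an estimate of 40 uM and a range from 15 uM to 100 uM. That expected estimate amounts to a step of a number no higher from compound 1 to compound 4 (the limit leaves the size open).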

Compound 4, concentration for 50% inhibition: > 40 uM
Compound 4 was reported as a limit (the forecaster's own chance of this, stated with the estimate: 75%); the middle value lies on the limit itself.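

In this assay compound 4 gives > 40 uM, which is a limit and not a number. Its steps from compound 1, compound 2 and compound 3 therefore cannot be read: the limit of > 40 uM in this assay, at which 4 of the 4 values shown sit.

The compounds shown leave open whether any group on the saturated chain carbon bound to an aromatic nitrogen changes the inhibition at all.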